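Swapping a phenyl for a cyclohexyl on the urea side chain

This account rests on a few compounds, and the source may have more. Where it says the series, first, only, none or still open, it means among the compounds named here.

Measured so far in a functional assay on L1210 cells (Mus musculus), read by MTT assay, with a stated time of 72 h; a higher number here means a weaker inhibitor, a lower number a stronger inhibitor:
Compound 1, `COc1cc(NC(C)CCCNC(=O)NC(c2ccccc2)c2ccccc2)c2ncccc2c1`: the value is a limit of the assay, > 500000 nM.
Compound 2, `COc1cc(NC(C)CCCNC(=O)NCc2ccncc2)c2ncccc2c1`: 3000 nM.
Compound 3, `COc1cc(NC(C)CCCNC(=O)NCc2ccccc2)c2ncccc2c1`: 22000 nM.

Among the two numbers given, compound 3 has the higher one. Its nearest neighbour is compound 2, with a 7.3-fold higher number from compound 2 to compound 3 (0.87 log units; beyond the scatter). Compound 1 sits at the limit of > 500000 nM in this assay, at which 1 of the 3 values shown sits, so it contributes only a limit, not a number, yet the step of an at least 22-fold lower number from compound 1 to compound 3 (1.35 log units; beyond the scatter) shows that removing the second phenyl from that chain carbon lowered the number by a wide margin.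

The next compound, compound 4, `COc1cc(NC(C)CCCNC(=O)NCC2CCCCC2)c2ncccc2c1`, differs from compound 3 in one place: cyclohexyl in place of phenyl on a saturated chain carbon bound to an amide-type nitrogen. Among the compounds with values here, no measured pair makes exactly this exchange. The two steps that touch the same chain carbon point in opposite directions and differ in size, so they set bounds rather than a direction. A change of modest size, in either direction, is therefore expected, with a slight lean towards a higher number, as a 1.4-fold higher number from compound 3 to compound 4 (0.13 log units; within the scatter). For compound 4 the estimate in this assay is 30000 nM, between 8000 nM and 120000 nM.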

Compound 4, half-maximal inhibitory concentration: 22000 nM
Compound 4: the middle estimate sits 1.4-fold (0.13 log units) above what was measured; the range from low to high includes it.
By their numbers in this assay, from the lowest: compound 2; then compounds 3 and 4 (each within the scatter of the next). At a limit, above all of these: compound 1.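

Swapping an aromatic ring of carbon for a non-aromatic one at this place makes no measurable difference in this assay, with no change at the digits printed from compound 3 to compound 4 (within the scatter), so this is the first sign that aromaticity in an all-carbon ring does not set the number here. Compound 2 stays apart from this ring as well, with a 7.3-fold higher number from compound 2 to compound 4 (0.87 log units; beyond the scatter), which makes pyridin-4-yl the only one of the three single rings on this chain carbon to stand out from the others. Nothing in the data shown gives a reason for this result.

On these data alone, what remains open is whether the lower number of compound 2 depends on where the ring nitrogen sits, which pyridin-3-yl or pyridin-2-yl would test. Piperidin-4-yl would show whether that ring nitrogen still serves in a non-aromatic ring.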